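The source may report more compounds than this note shows. Statements on the series, on what has been measured and on what is new or still open speak of the compounds shown alone.

Measured compounds, inhibition read in a functional assay for inhibition, with Homo sapiens as the target; on this read-out lower numbers stand for stronger inhibition and higher numbers for weaker inhibition:
- compound 1 `CCc1ccc(Nc2nccc(-c3cnccn3)n2)cc1`: 1900 nM
- compound 2 `CCc1ccc(Nc2nccc(-c3ccccn3)n2)cc1`: 2100 nM
- compound 3 `CCc1ccc(Nc2nccc(-c3cc(C)oc3C)n2)cc1`: 19200 nM

Compound 2 gives the second highest of the three numbers; its nearest neighbour is compound 1, at a 1.1-fold higher number from compound 1 to compound 2 (0.04 log units; within the scatter), a gap within the scatter, while compound 3 stands furthest away, at a 9.1-fold higher number from compound 2 to compound 3 (0.96 log units; beyond the scatter). Within the shared core of compound 2, the next compound, compound 4 `NS(=O)(=O)c1ccc(Nc2nccc(-c3ccccn3)n2)cc1`, keeps the pyridin-2-yl group and alters the other end: sulfamoyl in place of ethyl on an aromatic carbon.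

Within the data shown here, none of the measured steps bears on this change. Each of them, a 1.1-fold higher number from compound 1 to compound 2 (0.04 log units; within the scatter), a 10-fold higher number from compound 1 to compound 3 (1.00 log units; beyond the scatter) and a 9.1-fold higher number from compound 2 to compound 3 (0.96 log units; beyond the scatter), exchanges the heteroaryl group on the core and leaves the ethyl untouched, so nothing measured here tells how the sulfamoyl in place of ethyl will read in this assay. Among the measured compounds shown here, with no relevant step, no direction is expected beyond the scatter, but the uncertainty is wide. Compound 4 is estimated at 1500 nM, with a range from 200 nM to 10000 nM. The expected step is a 1.4-fold lower number from compound 2 to compound 4 (0.15 log units; within the scatter), a movement estimated to fall within the scatter.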

Compound 4, half-maximal inhibitory concentration: 4600 nM
Compound 4: the middle estimate sits 3.1-fold (0.49 log units) below what was measured; the range from low to high includes it.
By their numbers in this assay, from the lowest: compounds 1 and 2 (each within the scatter of the next); then compound 4; then compound 3.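

Among these compounds, replacing ethyl with sulfamoyl on this aromatic carbon, para to a large group, gives the first measured change at this end of the molecule in this assay (a 2.2-fold higher number from compound 2 to compound 4 (0.34 log units; beyond the scatter)), a modest step towards weaker inhibition. The position therefore responds to this exchange, although the step is smaller than the one seen when the heteroaryl group changes (a 9.1-fold higher number from compound 2 to compound 3 (0.96 log units; beyond the scatter)). Nothing available on these compounds accounts for the step, so the change from ethyl to sulfamoyl stays unexplained.

With only ethyl and sulfamoyl shown at this position, it remains open how an amine, a carboxylic acid or a longer chain would read there. On these data alone, it is also open whether the same exchange would give a similar step with pyrazin-2-yl or 2,5-dimethylfuran-3-yl in place of pyridin-2-yl.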